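The source may report more compounds than this note shows. Statements on the series, on what has been measured and on what is new or still open speak of the compounds shown alone.

Compound 1 `Cc1cccc(Oc2nc(Nc3ccc(C#N)cc3)nc3ccccc23)c1`: 355000 nM
Compound 2 `COc1ccccc1Oc1nc(Nc2ccc(C#N)cc2)nc2ccccc12`: 150000 nM
Compound 3 `CCOc1cc(C#N)cc(OCC)c1Oc1nc(Nc2ccc(C#N)cc2)nc2ccccc12`: 108000 nM

In an ADME assay on MT4 cells (Homo sapiens) for cytotoxicity, read by MTT assay, with a stated time of 4 days (a higher number here means that more compound is tolerated, a lower number that less compound is tolerated), compound 2 sits between the other two: its gap to compound 3 lies within the scatter, while the step from compound 1 to compound 2 was a 2.4-fold lower number from compound 1 to compound 2 (0.37 log units; beyond the scatter), a modest drop. Compound 4 `COc1ccc(Oc2nc(Nc3ccc(C#N)cc3)nc3ccccc23)cc1` differs from compound 2 by 4-methoxyphenyl in place of 2-methoxyphenyl on an oxygen on an aromatic ring. For the measured compounds named here, no measured step moves the same group from one position to another; the only step at this oxygen, a 2.4-fold lower number from compound 1 to compound 2 (0.37 log units; beyond the scatter), changed both the group and its position and stayed modest. A shift of the same methoxy group is therefore expected to give no step beyond the scatter in this assay, with a 1.1-fold lower number from compound 2 to compound 4 (0.03 log units; within the scatter). Compound 4 is estimated at 140000 nM, in a range from 60000 nM to 330000 nM.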

Compound 4, half-maximal cytotoxic concentration: 340000 nM
Estimate against measurement, compound 4: 2.4-fold (0.39 log units) below; the measured number lies above the stated range.
By their numbers in this assay, from the lowest: compounds 3 and 2 (each within the scatter of the next); then compounds 4 and 1 (each within the scatter of the next).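

Moving the methoxy group alone changes the result in this assay: 4-methoxyphenyl in place of 2-methoxyphenyl on the oxygen gives a 2.3-fold higher number from compound 2 to compound 4 (0.36 log units; beyond the scatter), so for this pair the position of the group counts, not only its presence. Replacing 3-methylphenyl with 4-methoxyphenyl gives a 1.0-fold lower number from compound 1 to compound 4 (0.02 log units; within the scatter), so this assay does not separate those two compounds. No supporting measurement accounts for the difference between the two methoxy positions. Still open, going by these compounds, is how an amine or a longer chain in place of the methoxy group would behave at this oxygen-linked ring.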